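A few compounds are considered here, and "the series" means these few. Any claim that something is new, unique, unknown or untested is made for them only; others in the source may bear on it.

The read-out followed here is a functional assay on HEL cells (Homo sapiens); on this read-out higher numbers stand for lower toxicity in this test and lower numbers for higher toxicity in this test. Two compounds have been run in it so far. Compound 1 `O=C1c2ccccc2N(COCc2ccccc2)S(=O)(=O)N1Cc1ccccc1` reaches only the edge of the test: in this assay compound 1 gives > 50 ug/mL, which is a limit and not a number. Compound 2 `CC(=O)OCCOCN1c2ccccc2C(=O)NS1(=O)=O` likewise reaches an edge: in this assay compound 2 gives > 200 ug/mL, again a limit rather than a number. So compound 2 stands at the limit of > 200 ug/mL in this assay, at which 1 of the 2 values shown sits, while the other value sits at the limit of > 50 ug/mL in this assay, at which 1 of the 2 values shown sits; since neither is a measured number, no step between the two can be sized.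

Compound 3 `CCCOCN1c2ccccc2C(=O)NS1(=O)=O` has not yet been measured in this assay. It differs from compound 2 in one place: methyl in place of acetoxy on a saturated chain carbon, two bonds along the chain from an oxygen on a saturated carbon. Going by the values given here, with no measured step to build on, the step in this assay is expected to be a number no higher from compound 2 to compound 3 (the limit leaves the size open), in no clear direction and nothing beyond the usual scatter. For compound 3 the estimate in this assay is therefore 200 ug/mL, in a range from 80 ug/mL to 400 ug/mL, and the result is most likely to come back again as a limit only.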

Compound 3, half-maximal cytotoxic concentration: > 50 ug/mL
Compound 3 was reported as a limit; the forecaster's own chance of this, stated with the estimate: 70%; the middle value lies beyond the limit too.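

Compound 2 and compound 3 both come back from this assay as limits and not as numbers, so the step between them cannot be read. The compounds shown leave open where the true values lie and whether methyl in place of acetoxy at this place changes the read-out at all.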